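Acetyl for methylsulfonyl on a pyrazole nitrogen, second core

A few compounds are considered here, and "the series" means these few. Any claim that something is new, unique, unknown or untested is made for them only; others in the source may bear on it.

The study compares four amides that share a saturated bicyclic core carrying a methylurea, with a pyrazole attached to the central benzamide ring. In a functional assay on MV4-11 cells (Homo sapiens) for antiproliferative activity, with a stated time of 6 days, tested at 6.25 uM (on this read-out higher numbers stand for a stronger effect at the one concentration tested and lower numbers for a weaker effect), compound 1 `CNC(=O)N1CCCc2ccc(NC(=O)c3cccc(-c4cnn(S(C)(=O)=O)c4)c3)cc21` gives 18%, whereas compound 2 `CNC(=O)N1CCCc2ccc(NC(=O)c3cccc(-c4cnn(C(C)=O)c4)c3)cc21` gives 82%. The change between them is acetyl in place of methylsulfonyl on an aromatic nitrogen, and it made a step of a number 64 percentage points higher from compound 1 to compound 2 (beyond the scatter). Compound 3 `CNC(=O)N1CCCc2ccc(NC(=O)c3ccc(-c4cnn(S(C)(=O)=O)c4)cc3)cc21`, which carries the pyrazole on a different position of the benzamide ring, gives 40.2% in this assay; how the core of compound 3 differs from the core of compound 1 is not broken down here. Compound 4 `CNC(=O)N1CCCc2ccc(NC(=O)c3ccc(-c4cnn(C(C)=O)c4)cc3)cc21` differs from compound 3 by acetyl in place of methylsulfonyl on an aromatic nitrogen, the same change that turned compound 1 into compound 2. Because the step of a number 64 percentage points higher from compound 1 to compound 2 (beyond the scatter) was large and compound 3 already starts higher than compound 1, the step from compound 3 to compound 4 is expected to be a number 44.8 percentage points higher from compound 3 to compound 4 (beyond the scatter), limited by the ceiling of the read-out. The expectation for compound 4 in this assay is therefore 85%, within 60% to 100%.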

Compound 4, a percentage reported as inhibition, at one concentration (the size of the read-out at that concentration, not a potency): 83.8%
The estimate for compound 4 lay 1.2 percentage points above the measured number; the measured number falls inside the stated range.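

In this assay the swap of methylsulfonyl for acetyl on an aromatic nitrogen again raised the read-out, with a number 43.6 percentage points higher from compound 3 to compound 4 (beyond the scatter), so the direction of the change carried over from the core of compound 1 to the core of compound 3. The size of the step did not carry over, and the two steps differ: the same change on two cores in this assay, a number 64 percentage points higher (beyond the scatter) from compound 1 to compound 2 and a number 43.6 percentage points higher (beyond the scatter) from compound 3 to compound 4, 20.4 percentage points apart, beyond the scatter of two such steps With compound 2 at 82% and compound 4 at 83.8%, these are single-concentration effects and not potencies, so the pairs do not show whether the smaller step belongs to the core itself, to the higher starting value of compound 3 or to the top of the scale.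

The compounds shown leave open whether other groups on that nitrogen, such as a plain methyl, a propanoyl chain or a dimethylcarbamoyl group, would follow the acetyl. They also leave open whether the gain would persist on a core with a different urea, such as an ethylurea in place of the methylurea.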